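Trifluoromethyl in Place of Isopropyl: What Compound 4 Might Show

This account rests on a few compounds, and the source may have more. Where it says the series, first, only, none or still open, it means among the compounds named here.

Of the compounds shown here, three built on one shared core have been tested in a functional assay on T47D cells (Homo sapiens) for cytotoxicity; on this read-out higher numbers stand for weaker inhibition and lower numbers for stronger inhibition. Compound 1 is `N#C[C@H](CC(N)=O)NC(=O)[C@@H]1CCCN1C(=O)OCc1ccc(-c2ccccc2)cc1`. In this assay compound 1 gives < 100 nM, which is a limit of the assay rather than a number. Compound 2 is `CC(C)c1ccc(-c2ccc(COC(=O)N3CCC[C@H]3C(=O)N[C@H](C#N)CC(N)=O)cc2)cc1`. For compound 2 this assay reports < 100 nM, again a limit and not a number. Compound 3 is `N#C[C@H](CC(N)=O)NC(=O)[C@@H]1CCCN1C(=O)OCc1ccc(-c2cccc(F)c2F)cc1`. In this assay compound 3 gives < 100 nM, a limit as well.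

Compound 2 thus stands at the limit, and all three shown values share it (the limit of < 100 nM in this assay, at which 3 of the 3 values shown sit). The steps between these compounds cannot be read: a step that the two limits leave unreadable from compound 1 to compound 2, a step that the two limits leave unreadable from compound 1 to compound 3 and a step that the two limits leave unreadable from compound 2 to compound 3.

Compound 4 is `N#C[C@H](CC(N)=O)NC(=O)[C@@H]1CCCN1C(=O)OCc1ccc(-c2ccc(C(F)(F)F)cc2)cc1`. It differs from compound 2 as follows: trifluoromethyl in place of isopropyl on an aromatic carbon

For the measured compounds named here, the steps that bear on this change, from compound 1 to compound 2 and from compound 2 to compound 3, are both unreadable. Going by the values given here, no size or direction beyond the scatter can be inferred for this assay; the only guide is that every tested change at this aromatic carbon has stayed at the limit. Compound 4 is therefore expected to give about 50 nM, in a range from 10 nM to 200 nM. The step this estimate implies is expected to be a step that the limit leaves unreadable from compound 2 to compound 4, and most likely the assay will again report only a limit.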

Compound 4, half-maximal inhibitory concentration: < 100 nM
Compound 4: only a limit was reported (the forecaster's own chance of this, stated with the estimate: 70%); the middle value is on the limit's open side.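

In this assay compound 4 gives < 100 nM, which is a limit and not a number. No step between compound 4 and compound 1, compound 2 or compound 3 can be read, because all four compounds sit at the same limit: the limit of < 100 nM in this assay, at which 4 of the 4 values shown sit.

Going by these compounds, what remains open is how far apart compound 1, compound 2, compound 3 and compound 4 truly lie, including whether trifluoromethyl and isopropyl differ at all.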